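Benzyl Ether in Place of Isopropyl on a Bromochromone

The compounds below may be only part of what the source reports. "The series", "measured", "known", "first", "only" and "open" are said of these compounds alone.

All three measured compounds were tested in a functional assay on KBVIN cells (Homo sapiens) for antiproliferative activity, read by sulforhodamine B assay, with a stated time of 72 h; on this read-out lower numbers stand for stronger inhibition of growth and higher numbers for weaker inhibition of growth:

compound 1 `CCc1cc(=O)c2ccc(OCc3ccccc3)c(C)c2o1` gives 24800 nM
compound 2 `CCc1oc2c(C)c(OC)ccc2c(=O)c1Br` gives 23200 nM
compound 3 `CCc1oc2c(C)c(OC(C)C)ccc2c(=O)c1Br` gives 5840 nM

Compound 3 stands lowest of the three numbers, and both gaps to the others lie beyond the scatter; its nearest neighbour is compound 2, its furthest compound 1. The one single-place step among these compounds is a 4.0-fold lower number from compound 2 to compound 3 (0.60 log units; beyond the scatter), where a larger group on the same oxygen went with a lower number.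

Compound 4 `CCc1oc2c(C)c(OCc3ccccc3)ccc2c(=O)c1Br` differs from compound 3 in one place: benzyl in place of isopropyl on an oxygen on an aromatic ring. For the measured compounds named here, only that step between compound 2 and compound 3 bears on this change, and it was modest. Compound 1 also carries a benzyl group on that oxygen, yet differs from compound 4 elsewhere too; in this assay compound 1 gives 24800 nM, which shows only that a benzyl ether can sit at a high number, not what the change itself does. The expectation for compound 4 is therefore a step of about a 1.5-fold higher number from compound 3 to compound 4 (0.19 log units; within the scatter), which is not clearly beyond the scatter in either direction. The estimated value for compound 4 is 9000 nM, with a range from 2500 nM to 35000 nM.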

Compound 4, concentration for 50% growth inhibition: > 26700 nM
Compound 4: a limit, no number; the forecaster's own chance of this, stated with the estimate: 5%; middle value at least 2.9-fold (0.47 log units) away from the limit.
By their numbers in this assay, from the lowest: compound 3; then compounds 2 and 1 (each within the scatter of the next). At a limit, above all of these: compound 4.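

In this assay, a larger group on this oxygen on an aromatic ring does not simply go with a lower number. Isopropyl in place of methyl goes with a 4.0-fold lower number from compound 2 to compound 3 (0.60 log units; beyond the scatter). Benzyl in place of isopropyl goes with an at least 4.5-fold higher number from compound 3 to compound 4 (0.66 log units; beyond the scatter). The reading for compound 4 is a limit of the assay and not a number: the limit of > 26700 nM in this assay, at which 1 of the 4 values shown sits. Two further steps rest on this limit: phenyl in place of hydrogen on a saturated chain carbon bound to an oxygen on an aromatic ring goes with an at least 1.1-fold higher number from compound 2 to compound 4 (0.06 log units; that floor lies within the scatter), and bromo in place of hydrogen on an aromatic carbon goes with an at least 1.0-fold higher number from compound 1 to compound 4 (0.03 log units; that floor lies within the scatter). Both of these floors lie within the scatter, so neither benzyl against methyl on this oxygen nor bromo against hydrogen on the aromatic carbon has a measured size here, and of the groups shown on this oxygen of the bromo series, only isopropyl stands clear of the others.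

The compounds shown leave open how narrow this preference is, since an ethyl, a cyclopropylmethyl or a longer chain such as n-butyl on the same oxygen would show whether the low number belongs to isopropyl alone. They also leave open whether the ring of benzyl matters or only its size, a question that a cyclohexylmethyl group, or a benzyl carrying an amine, could address.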